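The source may report more compounds than this note shows. Statements on the series, on what has been measured and on what is new or still open speak of the compounds shown alone.

Three compounds have so far been measured in an ADME assay for lipophilicity; a higher number here means a more lipophilic compound, a lower number a more polar compound:

compound 1, `Cc1cc(=O)c(O)c(C)o1`, giving 0.44
compound 2, `CCc1oc(C)cc(=O)c1O`, giving 1.07
compound 3, `CCn1cccc(O)c1=O`, giving 0.2

Compound 1 and compound 2 share one core. Compound 2 differs from compound 1 by methyl in place of hydrogen on a saturated chain carbon bound to an aromatic carbon. That single change produced a number 0.63 log units higher from compound 1 to compound 2 (beyond the scatter). Compound 3 is built on another core; the difference between the two cores is not broken down here. Compound 3 and compound 1 give numbers that lie within the usual scatter of each other, so nothing can be said about which is the more polar of the two, whereas compound 2 stands beyond the scatter above compound 3.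

Compound 4, `CCCn1cccc(O)c1=O`, has not yet been measured. It differs from compound 3 by methyl in place of hydrogen on a saturated chain carbon, two bonds along the chain from an aromatic nitrogen. Going by the values given here, this is the same kind of change as the one that turned compound 1 into compound 2, not the same one: in compound 2 the added methyl sits on a saturated chain carbon bound to an aromatic carbon, while in compound 4 it sits on a saturated chain carbon, two bonds along the chain from an aromatic nitrogen. Because the same kind of change gave a number 0.63 log units higher from compound 1 to compound 2 (beyond the scatter), a step of comparable size is expected for compound 4, a number 0.55 log units higher from compound 3 to compound 4 (beyond the scatter). On that basis compound 4 is estimated at 0.75, with the result expected to fall between 0.4 and 1.1.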

Compound 4, distribution coefficient: 0.69
Beside the measured number, compound 4's estimate is 0.06 log units above it; the measured number falls inside the stated range.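

Going from ethyl to propyl, with the new methyl on a saturated chain carbon, two bonds along the chain from an aromatic nitrogen, gave a number 0.49 log units higher from compound 3 to compound 4 (beyond the scatter) in this assay. Set beside the earlier methyl step on the other core, this step cannot be told apart from it: the same change on two cores in this assay, a number 0.63 log units higher (beyond the scatter) from compound 1 to compound 2 and a number 0.49 log units higher (beyond the scatter) from compound 3 to compound 4, 0.14 log units apart, within the scatter of two such steps So, for these two pairs, the change carried from one core to the other with a step of similar size and the same direction, but two pairs show only that agreement: they do not establish a rule for other cores or other places on the chain, and they do not explain why the steps match, especially as the added methyl in compound 2 sits on a saturated chain carbon bound to an aromatic carbon instead.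

The compounds shown leave open whether a longer chain than propyl would keep adding steps of this size on either core, or whether the steps would shrink or grow. They also leave open how this assay would respond if an amine or a carboxylic acid took the place of the added methyl.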